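Trimethoxyphenyl for dimethoxyphenyl on the chalcone-bearing core

The source may report more compounds than this note shows. Statements on the series, on what has been measured and on what is new or still open speak of the compounds shown alone.

Measured so far in a functional assay on A549 cells (Homo sapiens) for antiproliferative activity, read by MTT assay, with a stated time of 24 h; on this read-out higher numbers stand for weaker inhibition and lower numbers for stronger inhibition:
compound 1 `COc1ccc(C(=O)/C=C/c2cc(-c3cc(OC)c(OC)c(OC)c3)n3nc(-c4ccccc4)cc3n2)cc1` gives 14600 nM;
compound 2 `COc1ccc(/C=C/C(=O)c2cc(-c3cc(OC)c(OC)c(OC)c3)n3nc(-c4ccccc4)cc3n2)cc1` gives 21200 nM;
compound 3 `COc1ccc(-c2cc(/C=C/C(=O)c3ccc(Cl)cc3)nc3cc(-c4ccccc4)nn23)cc1OC` gives 15400 nM.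

The three numbers sit close together; the step of a 1.5-fold higher number from compound 1 to compound 2 (0.16 log units; within the scatter) is within the scatter, and compound 3 lies within the scatter of both compound 1 and compound 2.

Compound 4 `COc1cc(-c2cc(/C=C/C(=O)c3ccc(Cl)cc3)nc3cc(-c4ccccc4)nn23)cc(OC)c1OC` differs from compound 3 by methoxy in place of hydrogen on an aromatic carbon. Going by the values given here, no measured pair carries that change, so no measured step bears on it directly; the only measured step, a 1.5-fold higher number from compound 1 to compound 2 (0.16 log units; within the scatter), concerns a different part of the molecule. Nothing here argues for a shift beyond the scatter in either direction. Compound 4 is therefore expected near compound 3, with a 1.0-fold lower number from compound 3 to compound 4 (0.01 log units; within the scatter) as the estimated step. The estimate for compound 4 in this assay is 15000 nM, with a range from 7000 nM to 32000 nM.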

Compound 4, half-maximal inhibitory concentration: 15500 nM
The estimate for compound 4 lay 1.0-fold (0.01 log units) below the measured number, and the stated range covers the measured number.
By their numbers in this assay, from the lowest: compounds 1, 3, 4 and 2 (each within the scatter of the next).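

In this assay the change from 3,4-dimethoxyphenyl to 3,4,5-trimethoxyphenyl gives a 1.0-fold higher number from compound 3 to compound 4 (0.00 log units; within the scatter) and so shows that this position takes the added methoxy with no shift beyond the scatter. The other two steps also stay within the scatter: chloro in place of methoxy gives a 1.1-fold higher number from compound 1 to compound 4 (0.03 log units; within the scatter) and the exchange of the chlorophenyl and methoxyphenyl enone side chains gives a 1.4-fold lower number from compound 2 to compound 4 (0.14 log units; within the scatter) on the same trimethoxyphenyl core. No supporting evidence bears on this flat result.

Open, from the compounds shown here alone, is whether an amine or a carboxylic acid at this position would move the number beyond the scatter.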